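Swapping the ring substituent on a shared core

A few compounds are considered here, and "the series" means these few. Any claim that something is new, unique, unknown or untested is made for them only; others in the source may bear on it.

Compound 1: `CN1CCN(c2ccc(Nc3ncc4nc(Nc5ccc(F)cc5)n([C@@H]5CCN(C(=O)OC(C)(C)C)C5)c4n3)cc2)CC1` — "not determined" (no result reported)
Compound 2: `CC(=O)Nc1cccc(-n2c(Nc3ccc(F)cc3)nc3cnc(Nc4ccc(N5CCN(C)CC5)cc4)nc32)c1` — "not determined" (no result reported)
Compound 3: `CN1CCN(c2ccc(Nc3ncc4nc(Nc5ccc(F)cc5)n([C@@H]5CCN(S(=O)(=O)C6CC6)C5)c4n3)cc2)CC1` — > 10000 nM

Three compounds share one core, and only one of them has a number to show. In a functional assay on NCI-H1975 cells (Homo sapiens) for antiproliferative activity, read by MTT assay, with a stated time of 72 h (on this read-out higher numbers stand for weaker inhibition and lower numbers for stronger inhibition), compound 1 and compound 2 have no reported result. Compound 3 was tested, and in this assay compound 3 gives > 10000 nM, which is a limit of the assay rather than a measured number. Among the three entries, compound 3 is therefore the only one with any reading, and that reading is the limit (the limit of > 10000 nM in this assay, at which 1 of the 3 values shown sits). Within the data shown here, no step between two measured compounds can be drawn here.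

The next compound, compound 4, is `CN1CCN(c2ccc(Nc3ncc4nc(Nc5ccc(F)cc5)n([C@H]5CCCN(C(=O)CO)C5)c4n3)cc2)CC1`. It differs from compound 3 in one place: 1-((hydroxymethyl)carbonyl)piperidin-3-yl in place of 1-(cyclopropylsulfonyl)pyrrolidin-3-yl on an aromatic nitrogen. The group on the aromatic nitrogen shrinks by one heavy atom, gains a hydrogen-bond donor, loses the sulfur, and moves from a five-membered to a six-membered ring.

With compound 3 sitting at a limit, no direction can be read from the data. Compound 4 is expected to lie somewhere around 3000 nM, within 300 nM to 30000 nM. The change expected from this estimate is an at least 3.3-fold lower number from compound 3 to compound 4 (0.52 log units; beyond the scatter), and a result again reported only as a limit would not be surprising.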

Compound 4, half-maximal inhibitory concentration: 750 nM
For compound 4 the middle estimate is 4.0-fold (0.60 log units) above the measured one; the range from low to high includes it.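

Compound 3 gives > 10000 nM in this assay, and this is a limit of the assay, not a number. Among these compounds, changing the group on the aromatic nitrogen gives an at least 13-fold lower number from compound 3 to compound 4 (1.12 log units; beyond the scatter), a large step, which shows that antiproliferative activity on the shared core responds strongly to what this position carries, and compound 4 provides the first actual number for that core. The real size of the step remains unknown, as one of its two ends is only a limit: the limit of > 10000 nM in this assay, at which 1 of the 4 values shown sits.

The swap changes several features at once: the ring goes from five-membered to six-membered, the sulfur leaves, and a hydrogen-bond donor enters, and the compounds shown cannot tell which of these changes matters. A 1-(cyclopropylsulfonyl)piperidin-3-yl group would test the six-membered ring with the sulfonyl group kept, while a 1-acetylpiperidin-3-yl group, which keeps the ring and carbonyl but lacks the hydroxyl, would test the role of that hydroxyl.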